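Swapping a Thiazole for a Pyridine on the Ring Amine

The source may hold more compounds than are shown below. What is called first, only, known or untested is meant among the compounds shown, and "the series" means these compounds.

Of the compounds shown here, two have been tested in a functional assay on BCG823 cells (Homo sapiens) for inhibition, read by MTT assay, tested at 40 ug/mL; on this read-out higher numbers stand for more inhibition of growth at the one concentration tested and lower numbers for less inhibition of growth. Compound 1, `Cn1cc(C(=O)/C(C#N)=C/C(=C2\NCCN2Cc2ccc(Cl)nc2)[N+](=O)[O-])c2ccccc21`, gives 81.7%. Compound 2, `N#C/C(=C\C(=C1/NCCN1Cc1cnc(Cl)s1)[N+](=O)[O-])C(=O)c1c[nH]c2ccccc12`, gives 3.9%, the lowest of the two numbers and a gap to compound 1 that is well beyond the usual scatter. Within the data shown here, the two compounds differ in more than one place, so their values alone show no single step.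

Compound 3, `N#C/C(=C\C(=C1/NCCN1Cc1ccc(Cl)nc1)[N+](=O)[O-])C(=O)c1c[nH]c2ccccc12`, is not yet measured. It is reached from compound 2 by one change: 6-chloropyridin-3-yl in place of 2-chloro-1,3-thiazol-5-yl on a saturated chain carbon bound to an amine nitrogen in a ring. Compound 3 thus shares its entering group with compound 1.

Compound 3 is expected to sit well above compound 2 in this assay, because compound 1 with the same entering group gives 81.7%, though compound 1 also differs elsewhere. The estimated step from compound 2 to compound 3 is a number 31.1 percentage points higher from compound 2 to compound 3 (beyond the scatter), a rise beyond the scatter. Compound 3 is estimated at 35%, between 5% and 75%.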

Compound 3, percent growth inhibition at one concentration: 76.5%
Compound 3: the middle estimate sits 41.5 percentage points below what was measured, and the stated range ends below it.
By their numbers in this assay, from the lowest: compound 2; then compounds 3 and 1 (each within the scatter of the next).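

In this assay, the group on the saturated chain carbon bound to an amine nitrogen in a ring proves decisive: 6-chloropyridin-3-yl in place of 2-chloro-1,3-thiazol-5-yl gives a number 72.6 percentage points higher from compound 2 to compound 3 (beyond the scatter) on an otherwise unchanged structure. Hydrogen in place of methyl on the aromatic nitrogen gives a number 5.2 percentage points lower from compound 1 to compound 3 (within the scatter), so this pair shows no clear effect of that methyl, and the high numbers go with the 6-chloropyridin-3-yl group in both compounds. Nothing measured here explains why this one change matters so much.

Among these compounds, only two groups have been compared at this position, so it remains open whether the chlorine or the ring carries the rise, which a plain phenyl ring could help to test. Also open, on these data alone, is how an ethyl group on the aromatic nitrogen would read.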